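Phenyl in place of thiophen-2-yl on the shared core

The compounds below may be only part of what the source reports. "The series", "measured", "known", "first", "only" and "open" are said of these compounds alone.

Among the measured compounds shown here, in a functional assay on MCF7 cells (Homo sapiens) for cytotoxicity, read by MTT assay, with a stated time of 96 h (on this read-out higher numbers stand for weaker inhibition and lower numbers for stronger inhibition), compound 1 `Cc1cc2c(c(=O)o1)C(c1cccs1)C(C#N)=C(N)O2` gives 15000 nM, the higher of the two numbers measured so far. Compound 2 `Cc1cc2c(c(=O)o1)C(c1c[nH]c3ccc(Br)cc13)C(C#N)=C(N)O2` gives 5000 nM, a lower number by more than the usual scatter. For the measured compounds named here, compound 1 therefore marks the weaker end of a very short range, with compound 2 as its only neighbour.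

The next compound, compound 3 `Cc1cc2c(c(=O)o1)C(c1ccccc1)C(C#N)=C(N)O2`, keeps the core of compound 1 and carries phenyl in place of thiophen-2-yl on a saturated ring carbon. Going by the values given here, no measured step isolates this exchange, and the two measured compounds do not differ in one place only. Both the leaving and the entering group are a single aromatic ring with no net charge. The expectation rests on compound 1 at 15000 nM as the closest measured compound. In this assay the expected step of a 1.3-fold lower number from compound 1 to compound 3 (0.10 log units; within the scatter) is small, slightly towards a lower number and not expected to exceed the scatter. For compound 3 the estimated value is 12000 nM, with an expected range from 5000 nM to 30000 nM.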

Compound 3, half-maximal inhibitory concentration: 46000 nM
Compound 3: the middle estimate sits 3.8-fold (0.58 log units) below what was measured; measured number outside the range, above it.
By their numbers in this assay, from the lowest: compound 2; then compound 1; then compound 3.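

The saturated ring carbon does not treat these two single, uncharged aromatic rings as interchangeable: in this assay, phenyl in place of thiophen-2-yl gives a 3.1-fold higher number from compound 1 to compound 3 (0.49 log units; beyond the scatter) on the shared core, a modest step. Among the compounds shown here, this is the first comparison that isolates one change at this position, and it ranks thiophen-2-yl ahead of phenyl in this assay, since the higher number stands for weaker inhibition. The exchange swaps a five-membered aromatic ring with 1 hetero atom for a six-membered aromatic ring of carbon only, and this single pair cannot separate ring size from the loss of the sulfur; nothing at hand accounts for the step.

Furan-2-yl and thiophen-3-yl would test whether the ring size or the hetero atom and its place follow the step, while cyclohexyl would test whether an aromatic ring is needed on this carbon at all. Going by these compounds, whether a chloro or methoxy substituent on the phenyl of compound 3 shifts the number in either direction also stays open.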